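Thiophene in place of oxadiazole on a pyrrolopyridine amide

This account rests on a few compounds, and the source may have more. Where it says the series, first, only, none or still open, it means among the compounds named here.

Measured compounds:
compound 1 `Cc1c(NC(=O)c2ccc(C(C)(C)C)cc2)cccc1-c1ccnc2[nH]c(-c3ccc(C(=O)N4CCOCC4)cc3)nc12` with 0.02 10^-6 cm/s
compound 2 `Cn1cc(-c2nc3c(-c4ccc(CNC(=O)c5nc(C(C)(C)C)no5)c(F)c4)ccnc3[nH]2)cn1` with 11 10^-6 cm/s

In an ADME assay on Caco-2 cells (Homo sapiens) for permeability, in the apical to basolateral direction (a lower number here means that the compound crosses the layer more slowly, a higher number that the compound crosses the layer faster), compound 2 gives 11 10^-6 cm/s, the highest of the two numbers. In this assay compound 1 gives 0.02 10^-6 cm/s, a far lower figure, and the gap between compound 1 and compound 2 lies well beyond the scatter. Among the measured compounds shown here, no step between compounds differing in one place is available, so the two values are all that can be said of that pair.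

Compound 3 `Cn1cc(-c2nc3c(-c4ccc(CNC(=O)c5cc6c(s5)CCCC6)c(F)c4)ccnc3[nH]2)cn1` is not yet measured. It differs from compound 2 as follows: a group of 9 heavy atoms (8 carbon, 1 sulfur; one five-membered aromatic ring with 1 hetero atom, one six-membered non-aromatic ring of carbon only) in place of a group of 9 heavy atoms (6 carbon, 2 nitrogen, 1 oxygen; one five-membered aromatic ring with 3 hetero atoms), on a carbonyl carbon. For the measured compounds named here, no measured pair shows what such a change does here, so the expected step of a 1.1-fold higher number from compound 2 to compound 3 (0.04 log units; within the scatter) is held within the scatter, with no direction claimed. Compound 3 is therefore estimated at 12 10^-6 cm/s, with a range from 5 10^-6 cm/s to 28 10^-6 cm/s.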

Compound 3, apparent permeability: 0.6 10^-6 cm/s
Compound 3: middle estimate off by 20-fold (1.30 log units), on the high side, and the stated range ends above it.
By their numbers in this assay, from the lowest: compound 1; then compound 3; then compound 2.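

The first step from a single change shows that this site, on a carbonyl carbon whose other neighbour is an amide-type nitrogen, is not indifferent in this assay: the swap gives an 18-fold lower number from compound 2 to compound 3 (1.26 log units; beyond the scatter) even though the heavy-atom count stays at 9, neither group has a hydrogen-bond donor or a net charge, and the hydrogen-bond acceptor count goes from 3 to 1. Compound 1 could not show this, since it differs from compound 2 in more than one place. No measurement offered here bears on the reason for this step.

From the compounds shown here alone, it remains open whether the five-membered aromatic ring with 1 hetero atom or the six-membered non-aromatic ring of carbon only carries the step. Going by these compounds, how an unfused thiophene or a pyridine on the same carbonyl carbon would behave in this assay also remains open.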